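Extending the terminal amine of compound 1

A few compounds are considered here, and "the series" means these few. Any claim that something is new, unique, unknown or untested is made for them only; others in the source may bear on it.

Measured in a functional assay on CCRF-CEM cells (Homo sapiens) for inhibition, read by MTT assay, with a stated time of 4 days (on this read-out lower numbers stand for stronger inhibition and higher numbers for weaker inhibition), as follows:
- compound 1 (`COc1cc(NC(C)CCCNC(=O)NN)c2ncccc2c1`) gives (> 250000 nM), a limit and not a number
- compound 2 (`O=C(NC(c1ccccc1)c1ccc(Cl)cc1)n1nnc2ccccc21`) gives (116000 nM)

Compound 1 stands at the limit of > 250000 nM in this assay, at which 1 of the 2 values shown sits, so no number is available for it, only a limit. Compound 3 (`COc1cc(NC(C)CCCNC(=O)NNC(=O)NCCCO)c2ncccc2c1`) keeps the core of compound 1 and carries (3-hydroxypropyl)carbamoyl in place of hydrogen on an amine nitrogen. For the measured compounds named here, no measured pair shows this change, so the expectation is loosely bounded. A modest gain in inhibition is expected, although a second reading at the limit remains possible. The estimated size of the step is (an at least 3.5-fold lower number from compound 1 to compound 3 (0.55 log units; beyond the scatter)), toward lower numbers in this assay on this reasoning. For compound 3 the estimated value is (70000 nM), with an expected range from (15000 nM) to (250000 nM).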

Compound 3, half-maximal inhibitory concentration: > 250000 nM
Compound 3: only a limit was reported; the forecaster's own chance of this, stated with the estimate: 30%; at least 3.5-fold (0.55 log units) between middle value and limit.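

No step can be read from compound 1 to compound 3, because both readings are limits and not numbers: the limit of > 250000 nM in this assay, at which 2 of the 3 values shown sit.

Going by these compounds, whether (3-hydroxypropyl)carbamoyl in place of hydrogen on an amine nitrogen changes inhibition in this assay at all, and in which direction, stays open.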